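Alkylating the phenol of compound 3 with a decenyl chain

A few compounds are considered here, and "the series" means these few. Any claim that something is new, unique, unknown or untested is made for them only; others in the source may bear on it.

Compound 3 `CCCC[C@]1(CC)CS(=O)(=O)c2cc(O)ccc2[C@@H](c2ccccc2)[C@H]1O` was tested in an assay on cells for inhibition of ileal sodium/bile acid cotransporter (Homo sapiens) (a lower number here means a stronger inhibitor, a higher number a weaker inhibitor), where compound 3 gives 90 nM. Two other compounds share its core. Compound 1 `CCCC[C@]1(CC)CS(=O)(=O)c2ccc(Br)cc2[C@@H](c2cccc(OC)c2)[C@H]1O` gives 70 nM, and compound 2 `CCCC[C@]1(CC)CS(=O)(=O)c2ccc(-c3ccccc3)cc2[C@@H](c2cccc(OC)c2)[C@H]1O` gives 180 nM. Compound 3 thus sits among three numbers that all lie within the usual scatter of one another, so no order among the three can be read from them. Among the measured compounds shown here, the one step measured, a 2.6-fold higher number from compound 1 to compound 2 (0.41 log units; beyond the scatter), exchanged one aromatic substituent of the core for a larger one.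

Compound 4 `C=CCCCCCCCCOc1ccc2c(c1)S(=O)(=O)C[C@@](CC)(CCCC)[C@H](O)[C@@H]2c1ccccc1` differs from compound 3 by dec-9-en-1-yl in place of hydrogen on an oxygen on an aromatic ring. For the measured compounds named here, no measured step touches this oxygen, so only the step from compound 1 to compound 2 bears on the change, and only loosely: it shows that enlarging a group on the aromatic ring of the core moved the number by a modest amount. A step of similar size, or none beyond the scatter, is therefore expected, and its direction cannot be settled from these data. The expected step for compound 4 is a 1.3-fold higher number from compound 3 to compound 4 (0.12 log units; within the scatter). Compound 4 is estimated at 120 nM, with a range from 40 nM to 400 nM.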

Compound 4, half-maximal inhibitory concentration: 16000 nM
Beside the measured number, compound 4's estimate is 130-fold (2.12 log units) below it, and the stated range ends below it.
By their numbers in this assay, from the lowest: compounds 1, 3 and 2 (each within the scatter of the next, the first and the last beyond it); then compound 4.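

In this assay, exchanging hydroxy for (dec-9-en-1-yl)oxy gives a 180-fold higher number from compound 3 to compound 4 (2.25 log units; beyond the scatter), a step of a different order from the only earlier one, a 2.6-fold higher number from compound 1 to compound 2 (0.41 log units; beyond the scatter), which also enlarged a group on the aromatic ring of the shared core. This oxygen on an aromatic ring is therefore a place where a change can cost far more in this assay than the earlier step suggested, and adding a group to the core here does not leave the number within the scatter. Nothing among the data shown accounts for this large step.

The compounds shown leave open whether the step comes from replacing the hydrogen on this oxygen at all or from the length of the dec-9-en-1-yl chain, a question that a methyl or butyl ether at the same oxygen would address. They also leave open whether a chain of this length ending in a carboxylic acid or an amine, rather than in a double bond, would give a similar number.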